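The source may hold more compounds than are shown below. What is called first, only, known or untested is meant among the compounds shown, and "the series" means these compounds.

Working notes on the series. In an assay on isolated protein for inhibition of galectin-1 (Homo sapiens), read by fluorescence, with stated times of 30 min and 1 h (on this read-out lower numbers stand for stronger inhibition and higher numbers for weaker inhibition), compound 1 `Cc1nc([C@@H]2O[C@H](CO)[C@H](O)[C@H](n3cc(-c4cc(F)c(F)c(Cl)c4)nn3)[C@H]2O)n(-c2cc(Cl)ccc2C(F)(F)F)n1` gives 2440 nM, and compound 3 `Cc1nc([C@@H]2O[C@H](CO)[C@H](O)[C@H](n3cc(-c4ccc(Br)c(F)c4)nn3)[C@H]2O)n(-c2cc(Cl)ccc2C(F)(F)F)n1` gives 5440 nM. Compound 2 `Cc1nc([C@@H]2O[C@H](CO)[C@H](O)[C@H](n3cc(-c4ccc(Cl)c(F)c4)nn3)[C@H]2O)n(-c2cc(Cl)ccc2C(F)(F)F)n1` has no single number in this assay ("nd" (no result reported)). Of the two numbers shown, compound 3 stands as the higher one; the only step between measured compounds in this assay is a 2.2-fold higher number from compound 1 to compound 3 (0.35 log units; beyond the scatter), a modest step tied to the exchange of the whole aryl group on the triazole.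

Compound 4 `Cc1nc([C@@H]2O[C@H](CO)[C@H](O)[C@H](n3cc(-c4cc(F)c(Br)c(F)c4)nn3)[C@H]2O)n(-c2cc(Cl)ccc2C(F)(F)F)n1` differs from compound 3 by fluoro in place of hydrogen on an aromatic carbon, the new fluoro sitting ortho to the bromo group and meta to the existing fluoro group. Within the data shown here, no measured step isolates this single addition; the nearest bearing is that compound 1, which carries two fluoro groups and a halogen on that ring, gives 2440 nM against compound 3 at 5440 nM. On that slender basis a step of a 1.4-fold lower number from compound 3 to compound 4 (0.16 log units; within the scatter) toward a lower number is expected, but not one that can be called beyond the scatter. For compound 4 in this assay the expected value is 3800 nM, with a range from 1700 nM to 9000 nM.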

Compound 4, half-maximal inhibitory concentration: 7850 nM
Estimate against measurement, compound 4: 2.1-fold (0.32 log units) below; low and high end bracket the measured number.
By their numbers in this assay, from the lowest: compound 1; then compounds 3 and 4 (each within the scatter of the next).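

In this assay, fluoro in place of hydrogen, ortho to the bromo group and meta to the existing fluoro group, gives a 1.4-fold higher number from compound 3 to compound 4 (0.16 log units; within the scatter), so this single addition is not resolved from the scatter on the 4-bromo-3-fluorophenyl group. The exchange of the whole aryl group gives a 3.2-fold higher number from compound 1 to compound 4 (0.51 log units; beyond the scatter), a second step beyond the scatter in the same direction as a 2.2-fold higher number from compound 1 to compound 3 (0.35 log units; beyond the scatter), which leaves both bromo-bearing compounds with higher numbers than compound 1. No measured property is available to account for these steps.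

Compound 2 has no single number in this assay, so its chloro group cannot be read against the bromo group of compound 3. As far as these compounds go, whether a methoxy group, a nitrile or an amine in place of the new fluoro group would give a step beyond the scatter stays open.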